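Extending the Side Chain: From Three Measurements to Compound 4

This account rests on a few compounds, and the source may have more. Where it says the series, first, only, none or still open, it means among the compounds named here.

Three compounds share a core and differ at two places. Compound 1 `CC(=O)NNC(=O)c1csc2ncc(-c3ccc(C)cc3)n12` is the starting point; in a functional assay on HepG2 cells (Homo sapiens) for antiproliferative activity, read by MTT assay, with a stated time of 72 h (on this read-out higher numbers stand for weaker inhibition and lower numbers for stronger inhibition), compound 1 gives 63600 nM. Compound 2 `CCC(=O)NNC(=O)c1csc2ncc(-c3ccc(C)cc3)n12` carries methyl in place of hydrogen on a saturated chain carbon bound to a carbonyl carbon, and in this assay compound 2 gives 7340 nM, so that an 8.7-fold lower number from compound 1 to compound 2 (0.94 log units; beyond the scatter). Compound 3 `CCC(=O)NNC(=O)c1csc2ncc(-c3ccc(OC)cc3)n12` keeps that longer chain but replaces the methyl on the aromatic ring with methoxy; in this assay compound 3 gives 45800 nM, and a 6.2-fold higher number from compound 2 to compound 3 (0.80 log units; beyond the scatter). The difference between compound 1 and compound 3 is not broken down here, since they differ in two places; their values lie within the scatter of each other.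

Compound 4 `CCCC(=O)NNC(=O)c1csc2ncc(-c3ccc(OC)cc3)n12` has not been measured. Relative to compound 3 it carries methyl in place of hydrogen on a saturated chain carbon, two bonds along the chain from a carbonyl carbon. For the measured compounds named here, this is the same kind of change as the one from compound 1 to compound 2, and it occurs in two pairs of compounds; but it is not the same change. The earlier methyl entered on a saturated chain carbon bound to a carbonyl carbon, whereas here it enters two bonds along the chain from a carbonyl carbon. The earlier step was an 8.7-fold lower number from compound 1 to compound 2 (0.94 log units; beyond the scatter). Given that the place differs, the expected step for compound 4 is smaller, a 3.1-fold lower number from compound 3 to compound 4 (0.48 log units; beyond the scatter). In this assay compound 4 is therefore estimated at 15000 nM, most likely between 4000 nM and 50000 nM.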

Compound 4, half-maximal inhibitory concentration: 38000 nM
For compound 4 the middle estimate is 2.5-fold (0.40 log units) below the measured one, and the stated range covers the measured number.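

In this assay the extra methyl on the side chain gives a 1.2-fold lower number from compound 3 to compound 4 (0.08 log units; within the scatter), a step too small to count as a real difference between these two compounds. Set beside the earlier step, this shows that the size of the step seen with the methyl-bearing aromatic ring cannot simply be copied to the methoxy-bearing one, since the two steps clearly disagree: the same change on two cores in this assay, an 8.7-fold lower number (0.94 log units; beyond the scatter) from compound 1 to compound 2 and a 1.2-fold lower number (0.08 log units; within the scatter) from compound 3 to compound 4, 7.2-fold (0.86 log units) apart, beyond the scatter of two such steps What this does not show is why they disagree, as the two pairs differ both in the group on the aromatic ring and in the place where the methyl enters, and two pairs cannot separate these two differences or support a general rule for the series.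

The compounds shown leave open how the propylcarbonyl chain of compound 4 would behave on the methyl-bearing ring of compound 2, a comparison that would help to tell the effect of the ring group from that of the chain position. They also leave open what a longer chain, or a chain ending in an amine or a carboxylic acid, would do on either ring.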